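Carbamoylmethyl in place of methylsulfonyl: cytotoxicity notes

The source may report more compounds than this note shows. Statements on the series, on what has been measured and on what is new or still open speak of the compounds shown alone.

In a toxicity assay on MT4 cells (Homo sapiens) for cytotoxicity, read by MTT assay, with a stated time of 7 days (on this read-out lower numbers stand for higher toxicity in this test and higher numbers for lower toxicity in this test), compound 1 `Cc1cc(C)cc(S(=O)(=O)c2c(C(=O)NC3CC4(CCN(C(=O)OC(C)(C)C)C4)C3)[nH]c3ccc(Cl)cc23)c1` gives 171000 nM. Compound 2 `Cc1cc(C)cc(S(=O)(=O)c2c(C(=O)NC3CC4(C3)CN(S(C)(=O)=O)C4)[nH]c3ccc(Cl)cc23)c1` gives only a limit of the assay, > 233000 nM. Compound 2 therefore stands at the limit of > 233000 nM in this assay, at which 1 of the 3 values shown sits. Within the data shown here, compound 3 `Cc1cc(C)cc(S(=O)(=O)c2c(C(=O)NC3CC4(CCN(CC(N)=O)CC4)C3)[nH]c3ccc(Cl)cc23)c1` also bears carbamoylmethyl and gives 3610 nM, the lowest number in this assay so far.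

Compound 4 `Cc1cc(C)cc(S(=O)(=O)c2c(C(=O)NC3CC4(C3)CN(CC(N)=O)C4)[nH]c3ccc(Cl)cc23)c1` has carbamoylmethyl in place of methylsulfonyl on an amine nitrogen in a ring. Among the measured compounds shown here, no measured pair isolates this change, so the expectation rests on the value of compound 3 at 3610 nM. A large move toward lower numbers is expected, the estimated step being an at least 9.3-fold lower number from compound 2 to compound 4 (0.96 log units; beyond the scatter). For compound 4 the estimated value is 25000 nM, with an expected range of 5000 nM to 120000 nM.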

Compound 4, half-maximal cytotoxic concentration: 6080 nM
Estimate against measurement, compound 4: 4.1-fold (0.61 log units) above, within the range that was stated.
By their numbers in this assay, from the lowest: compounds 3 and 4 (each within the scatter of the next); then compound 1. At a limit, above all of these: compound 2.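

On the amine nitrogen of the four-membered non-aromatic ring, the group on that nitrogen clearly sets the read-out: carbamoylmethyl in place of methylsulfonyl gives, in this assay, an at least 38-fold lower number from compound 2 to compound 4 (1.58 log units; beyond the scatter). Among these compounds, this is the first single change that can be read as a step. For compound 2 the value is a limit of the assay, not a number: the limit of > 233000 nM in this assay, at which 1 of the 4 values shown sits.

Open, from the compounds shown here alone, is how a carboxylic acid, a free amine or a longer chain on this nitrogen would read. Going by these compounds, whether the same change carries over to other ring systems also remains open.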